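The source may hold more compounds than are shown below. What is called first, only, known or untested is meant among the compounds shown, and "the series" means these compounds.

Measured so far in a functional assay on A549 cells (Homo sapiens) for antiproliferative activity, read by MTT assay, with a stated time of 72 h; on this read-out higher numbers stand for weaker inhibition and lower numbers for stronger inhibition:
compound 1 `Cn1ccc2c(Oc3ccc(NC(=O)c4cc5cccnc5n(-c5ccc(F)cc5)c4=O)cc3F)ccnc21` gives 280 nM;
compound 2 `COc1ccc(-n2c(=O)c(C(=O)Nc3ccc(Oc4ccnc5c4ccn5C)c(F)c3)cc3cccnc32)cc1` gives 2750 nM.

Of these two numbers compound 2 carries the higher one, that is the weaker inhibition, and the gap is beyond the scatter: a 9.8-fold higher number from compound 1 to compound 2 (0.99 log units; beyond the scatter) came with methoxy in place of fluoro on the aromatic carbon.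

Compound 3 `Cn1ccc2c(Oc3ccc(NC(=O)c4cc5cccnc5n(-c5ccc(F)c(Cl)c5)c4=O)cc3F)ccnc21` is the next in line. It differs from compound 2 by 3-chloro-4-fluorophenyl in place of 4-methoxyphenyl on an aromatic nitrogen. In effect the fluoro of compound 1 returns and a chloro is added to that ring. Within the data shown here, the only measured step that bears on this is the one between compound 1 and compound 2, which was sizable; reversing it should largely undo that rise. Among the measured compounds shown here, the added chloro has no measured counterpart, so its share is unknown. The expected step is a 9.2-fold lower number from compound 2 to compound 3 (0.96 log units; beyond the scatter). Compound 3 is therefore estimated at 300 nM, within 100 nM to 1000 nM.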

Compound 3, half-maximal inhibitory concentration: 3560 nM
For compound 3 the middle estimate is 12-fold (1.07 log units) below the measured one, outside the stated range (above it).
By their numbers in this assay, from the lowest: compound 1; then compounds 2 and 3 (each within the scatter of the next).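

In this assay a single chloro added to the 4-fluorophenyl ring on the aromatic nitrogen brings a 13-fold higher number from compound 1 to compound 3 (1.10 log units; beyond the scatter) and so keeping the fluoro does not by itself keep the lower number. Measured against 4-methoxyphenyl, the 3-chloro-4-fluorophenyl group shows a 1.3-fold higher number from compound 2 to compound 3 (0.11 log units; within the scatter) and so the two groups cannot be told apart in this assay at this position. Both changes to this ring, in compound 2 and compound 3, give weaker inhibition than compound 1, and nothing available explains why.

Still open, going by these compounds, is how a plain phenyl ring, or a ring carrying a methyl or an amine, would behave on this nitrogen. Also open, on these data alone, is whether a chloro on this ring without the fluoro would give a similar rise.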